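Halogen pattern swap on the pendant phenyl ring

A few compounds are considered here, and "the series" means these few. Any claim that something is new, unique, unknown or untested is made for them only; others in the source may bear on it.

Working notes on a small series tested in a functional assay on PC-3 cells (Homo sapiens) for antiproliferative activity, read by MTT assay, with a stated time of 72 h; a lower number here means a stronger inhibitor, a higher number a weaker inhibitor. Compound 1 `O=C(COc1ccc(C(=O)/C=C/c2ccc(Cl)cc2Cl)cc1)N[C@H]1CCOC1=O` gives 8040 nM, the lowest of the two numbers in this assay. Compound 3 `O=C1OCC[C@@H]1NC(=S)SCCOc1ccc([N+](=O)[O-])cc1` gives 32500 nM, and its gap from compound 1 lies beyond the scatter. Compound 2 `Cc1ccc(C(C)C)c(OCCSC(=S)N[C@H]2CCOC2=O)c1` gives > 64000 nM in this assay, which is a limit rather than a number. This value of compound 2 sits at the limit of > 64000 nM in this assay, at which 1 of the 3 values shown sits.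

Compound 4 `O=C(COc1ccc(C(=O)/C=C/c2ccc(F)c(F)c2)cc1)N[C@H]1CCOC1=O` is not yet measured in this assay. It differs from compound 1 by 3,4-difluorophenyl in place of 2,4-dichlorophenyl on a double-bonded chain carbon bound to a double-bonded chain carbon. Among the measured compounds shown here, no measured pair changes the halogen pattern on that ring, so no step of this kind is known here, and the expectation rests on compound 1 alone. The step expected is a 1.5-fold higher number from compound 1 to compound 4 (0.17 log units; within the scatter), read as a slight weakening or none beyond the scatter. Compound 4 is estimated at 12000 nM, with a range from 4000 nM to 40000 nM in this assay.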

Compound 4, half-maximal inhibitory concentration: 21900 nM
Beside the measured number, compound 4's estimate is 1.8-fold (0.26 log units) below it; the range from low to high includes it.
By their numbers in this assay, from the lowest: compound 1; then compounds 4 and 3 (each within the scatter of the next). At a limit, above all of these: compound 2.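

Among the compounds shown here, replacing 2,4-dichlorophenyl with 3,4-difluorophenyl gives a 2.7-fold higher number from compound 1 to compound 4 (0.44 log units; beyond the scatter) in this assay and is the only measured step at this position, so the series now shows that the number responds to the halogens on this ring. The two groups match in heavy-atom count, with no hydrogen-bond donors or acceptors in either, so the step appears with those counts unchanged and only the halogen and its pattern differing. Nothing measured here bears on the cause of this step.

The halogen and its pattern change together in this single step, and a 3,4-dichlorophenyl group on the same chain carbon would separate the two. Going by these compounds, how an unsubstituted phenyl group would compare with both halogenated rings also remains open.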